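Removing the Methyl from a Methoxy Group

A few compounds are considered here, and "the series" means these few. Any claim that something is new, unique, unknown or untested is made for them only; others in the source may bear on it.

Of the compounds shown here, three have so far been measured in a functional assay on SN12C cells (Homo sapiens) for inhibition, read by sulforhodamine B assay, with a stated time of 48 h; on this read-out higher numbers stand for weaker inhibition of growth and lower numbers for stronger inhibition of growth. Compound 2 `COc1cc(-c2nn(-c3cccc(NC(=O)Nc4cc(C(F)(F)F)cc(C(F)(F)F)c4)c3)cc2-c2ccncc2)ccc1Cl` gives 3320 nM, the lowest of the two numbers shown. Compound 3 `COc1cc(-c2nn(-c3cccc(NC(=O)Nc4cccc(C(F)(F)F)c4)c3)cc2-c2ccncc2)ccc1Cl` gives 21900 nM, and the step of a 6.6-fold higher number from compound 2 to compound 3 (0.82 log units; beyond the scatter) lies beyond the scatter. Compound 1 `O=C(Nc1cccc(-n2cc(-c3ccncc3)c(-c3ccc(Cl)c(O)c3)n2)c1)Nc1cccc(C(F)(F)F)c1` gives > 32500 nM, which is a limit of the assay rather than a number; this is the limit of > 32500 nM in this assay, at which 1 of the 3 values shown sits.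

Compound 4 `O=C(Nc1cccc(-n2cc(-c3ccncc3)c(-c3ccc(Cl)c(O)c3)n2)c1)Nc1cc(C(F)(F)F)cc(C(F)(F)F)c1` has not yet been measured. It differs from compound 2 in one place: hydrogen in place of methyl on an oxygen on an aromatic ring. The same change, run in the opposite direction, is seen once among the measured compounds, in the step of an at least 1.4-fold lower number from compound 1 to compound 3 (0.17 log units; that floor lies within the scatter). That step only sets a floor, since compound 1 is a limit, so the true gap between the two may be larger than the floor suggests. Carried over to compound 4, taking the methyl away is expected to raise the number, and the estimated step is a 2.7-fold higher number from compound 2 to compound 4 (0.43 log units; beyond the scatter). For compound 4 the expected value in this assay is 9000 nM, with a range from 3000 nM to 30000 nM, and there is a real chance that the assay reports only a limit.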

Compound 4, concentration for total growth inhibition: 5450 nM
The estimate for compound 4 lay 1.7-fold (0.22 log units) above the measured number; the measured number falls inside the stated range.
By their numbers in this assay, from the lowest: compounds 2 and 4 (each within the scatter of the next); then compound 3. At a limit, above all of these: compound 1.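

On the 4-chloro-3-methoxyphenyl group, methoxy gives way to hydroxy with a 1.6-fold higher number from compound 2 to compound 4 (0.22 log units; within the scatter) in this assay, so on this core the methyl on that oxygen makes no difference that this assay can resolve. The earlier pair gave only a floor for this change, whereas the new pair gives a measured step on a second core: the same change on two cores in this assay, an at least 1.4-fold lower number (0.17 log units; that floor lies within the scatter) from compound 1 to compound 3 and a 1.6-fold lower number (0.22 log units; within the scatter) from compound 4 to compound 2; the limit leaves it open whether they differ. The hydroxy compounds also respond to trifluoromethyl in place of hydrogen on an aromatic carbon, with an at least 5.9-fold lower number from compound 1 to compound 4 (0.77 log units; beyond the scatter), a step that starts from a limit of the assay and so gives only a floor, and the methoxy pair moves the same way: the same change on two cores in this assay, a 6.6-fold higher number (0.82 log units; beyond the scatter) from compound 2 to compound 3 and an at least 5.9-fold higher number (0.77 log units; beyond the scatter) from compound 4 to compound 1; the limit leaves it open whether they differ.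

The compounds shown leave open whether that oxygen would tolerate other groups, such as an ethyl group or a longer chain, or whether an amine could stand in place of the hydroxy. As far as these compounds go, the true value of compound 1 also remains unknown, so the full size of both changes on its core stays open.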